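Toward compound 3: swapping the aryl group on the urea

The source may hold more compounds than are shown below. What is called first, only, known or untested is meant among the compounds shown, and "the series" means these compounds.

Compound 1, `COc1cc(NC(C)CCCNC(=O)NNC(=O)Nc2ccc(O)cc2)c2ncccc2c1`, gives 2600 nM in a functional assay on MCF7 cells (Homo sapiens) for inhibition, read by MTT assay, with a stated time of 72 h; on this read-out higher numbers stand for weaker inhibition and lower numbers for stronger inhibition.
Compound 2, `COc1cc(NC(C)CCCNC(=O)NNC(=O)Nc2cccc(Cl)c2)c2ncccc2c1`, gives 220 nM in this assay.

Compound 2 stands lowest of the two numbers, with compound 1 giving a higher number by a 12-fold lower number from compound 1 to compound 2 (1.07 log units; beyond the scatter). Compound 3, `COc1cc(NC(C)CCCNC(=O)NNC(=O)Nc2ccc(F)cc2)c2ncccc2c1`, differs from compound 2 by 4-fluorophenyl in place of 3-chlorophenyl on an amide-type nitrogen. Within the data shown here, the only measured step, the one from compound 1 to compound 2, involves neither a 4-fluorophenyl nor a chlorine-to-fluorine exchange, so it bears on this change only loosely, showing that the aryl group can move the number a great deal. Compound 3 is therefore expected to show a modest rise, a 2.5-fold higher number from compound 2 to compound 3 (0.40 log units; beyond the scatter), and is estimated at 550 nM, in the range 150 nM to 2000 nM.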

Compound 3, half-maximal inhibitory concentration: 310 nM
Compound 3: the middle estimate sits 1.8-fold (0.25 log units) above what was measured, within the range that was stated.
By their numbers in this assay, from the lowest: compounds 2 and 3 (each within the scatter of the next); then compound 1.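

In this assay the change reads as a 1.4-fold higher number from compound 2 to compound 3 (0.15 log units; within the scatter): on this amide-type nitrogen, 4-fluorophenyl and 3-chlorophenyl give values that cannot be told apart. The other new step, an 8.4-fold lower number from compound 1 to compound 3 (0.92 log units; beyond the scatter), isolates a single exchange, fluoro in place of hydroxy on an aromatic carbon, and shows that this one exchange accounts for a change beyond the scatter. Nothing available explains either step.
From the compounds shown here alone, whether the halogen or its place on the ring matters remains open, as a 3-fluorophenyl or 4-chlorophenyl group would separate the two. Going by these compounds, how an amine or a carboxylic acid in place of the hydroxy would read also remains open.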